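The source may report more compounds than this note shows. Statements on the series, on what has been measured and on what is new or still open speak of the compounds shown alone.

Compound 3 `Cc1ccc(OCC(=O)N(Cc2cccs2)c2ccnn2C)cc1` gives 422 nM in an assay on HEK293 cells for agonist activity at transient receptor potential cation channel subfamily M member 8 (Homo sapiens), read by fluorescence and calcium flux, with a stated time of 15 min (on this read-out lower numbers stand for an effect already at smaller amounts and higher numbers for an effect only at larger amounts of compound), which places it second highest among the three measured compounds, far from compound 1 `Cc1ccc(OCC(=O)N(Cc2cccs2)c2ncco2)cc1` with 0.3 nM and nearer compound 2 `Cc1ccc(OCC(=O)N(Cc2cccs2)C2CCCCC2)cc1` with 40000 nM. Compound 4 `Cc1ccc(OCC(=O)N(Cc2cccs2)C(C)(C)C)cc1` differs from compound 3 by tert-butyl in place of 1-methyl-1H-pyrazol-5-yl on an amide-type nitrogen. Within the data shown here, two measured steps bear on this: the change a 130000-fold higher number from compound 1 to compound 2 (5.12 log units; beyond the scatter) and the change a 95-fold lower number from compound 2 to compound 3 (1.98 log units; beyond the scatter), both steps between a five-membered aromatic ring on that nitrogen and a saturated carbon group. Since tert-butyl is likewise a saturated carbon group without a ring, the step of a 71-fold higher number from compound 3 to compound 4 (1.85 log units; beyond the scatter) is expected to raise the number markedly. Compound 4 is therefore estimated at 30000 nM, within a range of 5000 nM to 100000 nM.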

Compound 4, half-maximal effective concentration: 11000 nM
Estimate against measurement, compound 4: 2.7-fold (0.44 log units) above, and the stated range covers the measured number.
By their numbers in this assay, from the lowest: compound 1; then compound 3; then compound 4; then compound 2.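

Replacing a five-membered aromatic ring on the amide-type nitrogen with tert-butyl gives a 26-fold higher number from compound 3 to compound 4 (1.42 log units; beyond the scatter) and a 37000-fold higher number from compound 1 to compound 4 (4.56 log units; beyond the scatter), so a second saturated carbon group, this one without a ring, also lies far above both aromatic rings. The two saturated groups stay much closer to each other, though still apart beyond the scatter, with a 3.6-fold lower number from compound 2 to compound 4 (0.56 log units; beyond the scatter). No available evidence accounts for these differences. As far as these compounds go, it remains open where a phenyl or 1,3-thiazol-2-yl group on that nitrogen would fall, and whether a smaller saturated group such as methyl would continue the small difference between tert-butyl and cyclohexyl.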